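The source may hold more compounds than are shown below. What is called first, only, known or untested is meant among the compounds shown, and "the series" means these compounds.

Compound 1 `O=C1Nc2ccccc2/C1=C\c1c(Cl)n(Cc2ccccc2)c2ccccc12` is the weaker of the two compounds measured in a functional assay on NSCLC cells (Homo sapiens) for cytotoxicity, with a stated time of 48 h; on this read-out lower numbers stand for stronger inhibition of growth and higher numbers for weaker inhibition of growth: in this assay compound 1 gives 14800 nM, the highest of the two numbers. Compound 2 `COc1cc2c(/C=C3/C(=O)Nc4cccc(Cl)c43)c(Cl)n(Cc3cc(OC)c(OC)c(OC)c3)c2cc1C` differs from compound 1 in several places at once. In this assay compound 2 gives 3240 nM, a stronger inhibition of growth than compound 1 shows and a gap that lies beyond the scatter.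

Compound 3 `O=C1Nc2ccccc2/C1=C\c1c(Cl)n(CCCc2ccccc2)c2ccccc12` is the one-place variation of compound 1: phenethyl in place of phenyl on a saturated chain carbon bound to an aromatic nitrogen, so that the benzyl on the aromatic nitrogen becomes a 3-phenylpropyl. Going by the values given here, no measured pair in this set reports what such a lengthening does, so there is no step to lean on. The expected step from compound 1 to compound 3 in this assay is therefore a 1.2-fold lower number from compound 1 to compound 3 (0.09 log units; within the scatter), a change within the scatter and with no clear direction. Compound 3 is thus estimated to give 12000 nM in this assay, with a range from 5000 nM to 35000 nM.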

Compound 3, concentration for 50% growth inhibition: 14100 nM
The estimate for compound 3 lay 1.2-fold (0.07 log units) below the measured number; the measured number falls inside the stated range.
By their numbers in this assay, from the lowest: compound 2; then compounds 3 and 1 (each within the scatter of the next).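

Lengthening the benzyl on the aromatic nitrogen to a 3-phenylpropyl gives the only single-place reading at this position, and in this assay the step is a 1.0-fold lower number from compound 1 to compound 3 (0.02 log units; within the scatter) and so does not separate the two compounds. In this one pair, the longer chain between the aromatic nitrogen and the phenyl leaves the read-out within the scatter, so this lengthening alone does not account for a stronger inhibition of growth. Nothing at hand explains why the two numbers agree.

Still open, on these data alone, is whether the phenyl itself matters here, for instance whether a morpholine or a carboxylic acid on the same chain would give a different number. Compound 2 differs from compound 1 in several places at once, so the compounds shown do not tell which of those places carries its stronger inhibition of growth.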